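Moving the chlorine on a series stuck at its limit

The source may report more compounds than this note shows. Statements on the series, on what has been measured and on what is new or still open speak of the compounds shown alone.

Compound 1 `COc1ccc(-c2nc3cccc(-c4cc(OC)c(OC)c(OC)c4)c3o2)cc1` gives > 25000 nM
Compound 2 `COc1ccc(-c2nc3cccc(-c4cc(OC)c(OC)c(OC)c4)c3o2)cc1OC` gives > 25000 nM
Compound 3 `COc1cc(-c2cccc3nc(-c4cccc(Cl)c4)oc23)cc(OC)c1OC` gives > 25000 nM

Compound 3 stands in a functional assay on MCF7 cells (Homo sapiens) for antiproliferative activity, read by MTT assay, with a stated time of 48 h (a higher number here means a weaker inhibitor, a lower number a stronger inhibitor), at > 25000 nM as a limit and not a number. All three compounds sit together at the limit of > 25000 nM in this assay, at which 3 of the 3 values shown sit, and no ranking can be drawn. Compound 4 `COc1cc(-c2cccc3nc(-c4ccc(Cl)cc4)oc23)cc(OC)c1OC` differs from compound 3 by one change 4-chlorophenyl in place of 3-chlorophenyl on an aromatic carbon with 4-chlorophenyl in place of 3-chlorophenyl on an aromatic carbon. Among the measured compounds shown here, three measured steps bear on this: a step that the two limits leave unreadable from compound 1 to compound 3 and a step that the two limits leave unreadable from compound 2 to compound 3 and also a step that the two limits leave unreadable from compound 1 to compound 2 in the same way. None gives a size or a direction. The expected change is a step that the limit leaves unreadable from compound 3 to compound 4 with no direction favoured. In this assay the estimate for compound 4 is 30000 nM with an expected range from 10000 nM to 60000 nM and a limit as the likely report.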

Compound 4, half-maximal inhibitory concentration: > 25000 nM
Compound 4: a limit, no number; the forecaster's own chance of this, stated with the estimate: 80%; the middle value does not contradict the limit.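

No new step can be read between compound 4 and compound 1, compound 2 or compound 3 in this assay, because each value is a limit and not a number: the limit of > 25000 nM in this assay, at which 4 of the 4 values shown sit.

The compounds shown leave open whether moving the chlorine changes activity at all, and how far any of them lies beyond the limit.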